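A few compounds are considered here, and "the series" means these few. Any claim that something is new, unique, unknown or untested is made for them only; others in the source may bear on it.

Compound 3 `CCCC(Nc1cncc(-c2ccc(NC(=O)NCC)c(CC)c2)n1)c1cccnc1` gives the lowest number of the three compounds measured in a functional assay on PC-3 cells (Homo sapiens) for cytotoxicity, read by MTT assay, with a stated time of 72 h (on this read-out lower numbers stand for stronger inhibition and higher numbers for weaker inhibition), at 160 nM. Compound 2 `CCCC(=O)Nc1ccc(-c2cncc(NC(CCC)c3cccnc3)n2)cc1OC` gives 600 nM in this assay, and compound 1 `CCCC(Nc1cncc(-c2ccc(NC(C)=O)c(OC)c2)n1)c1cccnc1` gives 5000 nM. Among the compounds with values here, the only single-point step measured so far is an 8.3-fold lower number from compound 1 to compound 2 (0.92 log units; beyond the scatter), and it concerns a chain carbon, not the aromatic ring.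

Compound 4 `CCCC(Nc1cncc(-c2ccc(NC(=O)NCC)c(OC)c2)n1)c1cccnc1` differs from compound 3 by methoxy in place of ethyl on an aromatic carbon. Within the data shown here, no measured step changes this ring position alone, so the expectation rests on looser ground. Compounds 1 and 2, which both carry a methoxy at that place, give higher numbers in this assay than compound 3, which carries an ethyl there, but they also differ from compound 3 at the carbonyl-bearing group, so their values cannot be read as a clean test of the ring substituent. On balance compound 4 is expected to give a somewhat higher number than compound 3, a step of about a 2.5-fold higher number from compound 3 to compound 4 (0.40 log units; beyond the scatter). The estimate for compound 4 in this assay is 400 nM, with a range from 120 nM to 1500 nM.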

Compound 4, half-maximal inhibitory concentration: 40 nM
Compound 4: middle estimate off by 10-fold (1.00 log units), on the high side; measured number below the stated range.
By their numbers in this assay, from the lowest: compound 4; then compound 3; then compound 2; then compound 1.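

Swapping ethyl for methoxy on this aromatic carbon gives a 4.0-fold lower number from compound 3 to compound 4 (0.60 log units; beyond the scatter) in this assay with nothing else changed, so here methoxy goes with the lower number. The earlier compounds shown here could not show this, since compounds 1 and 2 both carry methoxy and also differ at the carbonyl group. With methoxy held in place, ethylamino in place of propyl on the carbonyl carbon gives a 15-fold lower number from compound 2 to compound 4 (1.18 log units; beyond the scatter) and ethylamino in place of methyl gives a 130-fold lower number from compound 1 to compound 4 (2.10 log units; beyond the scatter) in the same assay, so the higher numbers of compounds 1 and 2 go with that carbonyl group and not with methoxy.

The data shown give no measured explanation for the effect of the ring swap. As far as these compounds go, how a hydroxyl, a chlorine or an ethoxy would compare at this ring carbon remains open, as does whether methoxy would keep its advantage over ethyl with propyl or methyl on the carbonyl carbon.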